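This account rests on a few compounds, and the source may have more. Where it says the series, first, only, none or still open, it means among the compounds named here.

Measured so far in a functional assay on Ishikawa cells (Homo sapiens) for antiproliferative activity, read by MTT assay, with a stated time of 48 h; a higher number here means a weaker inhibitor, a lower number a stronger inhibitor:
- compound 1 `CCN(CC)CC(=O)Nc1ccc(Nc2nc(-c3ccc(OC)cc3)nc(Cl)c2-c2ccccc2)cc1`: > 40000 nM, a limit
- compound 2 `COc1ccc(-c2nc(Cl)c(-c3ccccc3)c(Nc3ccc(NC(=O)CN4CCCC4)cc3)n2)cc1`: > 40000 nM, a limit
- compound 3 `COc1ccc(-c2nc(Cl)cc(Nc3ccc(NC(=O)CN(C)C)cc3)n2)cc1`: > 40000 nM, a limit

Compound 3 stands at > 40000 nM, which is a limit and not a number. Going by the values given here, the whole series so far offers only (the limit of > 40000 nM in this assay, at which 3 of the 3 values shown sit). Compound 4 `COc1ccc(-c2nc(Cl)c(-c3ccccc3)c(Nc3ccc(NC(=O)CN(C)C)cc3)n2)cc1` departs from compound 3 by one change, phenyl in place of hydrogen on an aromatic carbon.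

Among the compounds with values here, the one measured step, a step that the two limits leave unreadable from compound 1 to compound 2, lies elsewhere in the structure and gives no size for this change. Compound 2 carries phenyl at that same place and gives > 40000 nM, which is a limit. On that basis no direction can be given, and no step beyond the scatter is expected. The estimated step is a number no higher from compound 3 to compound 4 (the limit leaves the size open), and it rests on a limit rather than on a number. Compound 4 is expected at 40000 nM, with an estimated range of 15000 nM to 80000 nM, and the assay will most likely report only a limit again.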

Compound 4, half-maximal inhibitory concentration: 17100 nM
Compound 4: the middle estimate sits 2.3-fold (0.37 log units) above what was measured, and the stated range covers the measured number.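

In this assay, going by these compounds alone, phenyl in place of hydrogen on this aromatic carbon gives an at least 2.3-fold lower number from compound 3 to compound 4 (0.36 log units; beyond the scatter), the first change that can be read as a step. Phenyl does not do this alone, since the group on the chain also counts: dimethylamino in place of pyrrolidin-1-yl gives an at least 2.3-fold lower number from compound 2 to compound 4 (0.36 log units; beyond the scatter), and dimethylamino in place of diethylamino gives an at least 2.3-fold lower number from compound 1 to compound 4 (0.36 log units; beyond the scatter). Both of those compounds carry the same phenyl, and the step between them cannot be read.

From the compounds shown here alone, the true size of all three steps stays open, since each starts from a limit and not from a number: the limit of > 40000 nM in this assay, at which 3 of the 4 values shown sit. Also open is what methyl or 4-fluorophenyl would give on this aromatic carbon, or morpholin-4-yl on the chain.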